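Fluoro for methyl on the aniline ring of a thiophene acid

This account rests on a few compounds, and the source may have more. Where it says the series, first, only, none or still open, it means among the compounds named here.

Measured so far:
compound 1, `COc1ccc(C(=O)c2sc(Nc3ccccc3)c(C(=O)O)c2C)cc1` — 36.5%
compound 2, `COc1ccc(C(=O)c2sc(Nc3ccc(C)cc3)c(C(=O)O)c2C)cc1` — "not active" (no number reported)

The account concerns two measured compounds and one that awaits measurement. In a functional assay, with a stated time of 150 min, tested at 15 ug/mL (on this read-out higher numbers stand for a stronger effect at the one concentration tested and lower numbers for a weaker effect), compound 1 gives 36.5%. In this assay compound 2 is reported as "not active" (no number reported), so no single number stands for it; the account can only say that compound 2 shows less than compound 1 at the concentration tested.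

Compound 3, `COc1ccc(C(=O)c2sc(Nc3ccc(F)cc3)c(C(=O)O)c2C)cc1`, differs from compound 2 in one place: fluoro in place of methyl on an aromatic carbon. Among the measured compounds shown here, no step between two measured compounds of this kind is known, so the size of the change from compound 2 to compound 3 in this assay cannot be read from any measured pair. Compound 2 stands at the weak end, and the expectation is for a step of small size, if any, in either direction, most likely within the usual scatter. Compound 3 is therefore estimated to reach about 15% in this assay, with a range from 0% to 40%.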

Compound 3, a percentage reported as activity, at one concentration (the size of the read-out at that concentration, not a potency): 1.98%
Estimate against measurement, compound 3: 13 percentage points above; measured number inside the range.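

Replacing the hydrogen on the aromatic carbon para to a large group with fluoro has a clear cost in this assay: the result is a number 34.5 percentage points lower from compound 1 to compound 3 (beyond the scatter), which gives this position its first measured step, since compound 2 carries no number and could only be placed below compound 1. With compound 3, both compounds shown that bear a group at this place, methyl in compound 2 and fluoro in compound 3, sit below compound 1, so the unsubstituted aniline ring of compound 1 remains the only one here with a clear read-out, although the step from methyl to fluoro itself cannot be read, as compound 2 has no number. Nothing given here bears on why the read-out falls when fluoro enters at this place.

The compounds shown leave open whether a chloro, hydroxyl or methoxy group at the same place would behave as fluoro and methyl do, or whether any group there would lower the read-out. They also leave open how a fluoro group on another carbon of the aniline ring would read, and what an amide in place of the carboxylic acid would do.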